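This account rests on a few compounds, and the source may have more. Where it says the series, first, only, none or still open, it means among the compounds named here.

The shared core appears in compound 1 `CC(=O)N1c2ccccc2CCC1C(=O)Nc1ccccc1O` and compound 2 `O=C(Nc1ccccc1O)C1CCc2ccccc2N1C(=O)c1ccccc1Cl`. In a functional assay on ACHN cells (Homo sapiens) for cytotoxicity, read by sulforhodamine B assay, with a stated time of 72 h (a lower number here means a stronger inhibitor of growth, a higher number a weaker inhibitor of growth), compound 1 gives 50700 nM. In this assay compound 2 gives 44200 nM. For the measured compounds named here, the step of a 1.1-fold lower number from compound 1 to compound 2 (0.06 log units; within the scatter) is the only measured change of the group on the carbonyl carbon in this set, and it stayed inside the scatter.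

Compound 3 `CCC(=O)N1c2ccccc2CCC1C(=O)Nc1ccccc1C(F)(F)F` carries a propanoyl group. For compound 3 the result in this assay is only a limit, > 80000 nM, so its standing among the measured numbers is not known beyond the fact that it sits at the limit of > 80000 nM in this assay, at which 1 of the 3 values shown sits.

Compound 4 `O=C(Nc1ccccc1C(F)(F)F)C1CCc2ccccc2N1C(=O)c1ccccc1Cl` is to be measured in this assay. The change is 2-chlorophenyl in place of ethyl on a carbonyl carbon. Going by the values given here, the one measured step that bears on it, a 1.1-fold lower number from compound 1 to compound 2 (0.06 log units; within the scatter), gave no shift beyond the scatter, so none is expected here either; since compound 3 is a limit, a direction cannot be fixed. For compound 4 the expected value in this assay is 90000 nM, with a range from 40000 nM to 200000 nM. The implied step that the limit leaves unreadable from compound 3 to compound 4 is an estimate only.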

Compound 4, concentration for 50% growth inhibition: 3900 nM
Beside the measured number, compound 4's estimate is 23-fold (1.36 log units) above it, outside the stated range (below it).
By their numbers in this assay, from the lowest: compound 4; then compounds 2 and 1 (each within the scatter of the next). At a limit, above all of these: compound 3.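

In this assay, with trifluoromethyl on the aromatic carbon, 2-chlorophenyl in place of ethyl on the carbonyl carbon gives an at least 20-fold lower number from compound 3 to compound 4 (1.31 log units; beyond the scatter), whereas the same group in place of methyl, with hydroxy on the aromatic carbon, gave only a 1.1-fold lower number from compound 1 to compound 2 (0.06 log units; within the scatter). The group on the carbonyl carbon therefore does not act the same way in both settings, and with 2-chlorophenyl held fixed the aromatic substituent also counts: trifluoromethyl in place of hydroxy on the aromatic carbon gives an 11-fold lower number from compound 2 to compound 4 (1.05 log units; beyond the scatter). Compound 3 stands at a limit, not at a number: the limit of > 80000 nM in this assay, at which 1 of the 4 values shown sits.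

Open, from the compounds shown here alone, is how a plain phenyl or a cyclohexyl on the carbonyl carbon would compare with 2-chlorophenyl alongside trifluoromethyl. Also open, going by these compounds, is whether a chlorine or a nitrile in place of trifluoromethyl on the aromatic carbon would hold the number of compound 4.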